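This account rests on a few compounds, and the source may have more. Where it says the series, first, only, none or still open, it means among the compounds named here.

Compound 1 `C#CCSc1nc(Sc2nncs2)c(C#N)c(-c2cc(OC)c(OC)c(OC)c2)n1` - 4660 nM
Compound 2 `C#CCSc1nc(Sc2nc3ccccc3s2)c(C#N)c(-c2cc(OC)c(OC)c(OC)c2)n1` - > 20000 nM (a limit)

In a functional assay on SMMC-7721 cells (Homo sapiens) for antiproliferative activity, read by MTT assay, with a stated time of 72 h (on this read-out lower numbers stand for stronger inhibition and higher numbers for weaker inhibition), compound 1 gives 4660 nM as a measured number. Compound 2 stands at > 20000 nM as a limit of the assay and not a number.

Among the measured compounds shown here, the one measured step, an at least 4.2-fold higher number from compound 1 to compound 2 (0.63 log units; beyond the scatter), lies beyond the scatter and comes with 1,3-benzothiazol-2-yl in place of 1,3,4-thiadiazol-2-yl on a sulfur. Compound 3 `C#CCSc1nc(Sc2nc(C)cs2)c(C#N)c(-c2cc(OC)c(OC)c(OC)c2)n1` differs from compound 2 on that same sulfur by 4-methyl-1,3-thiazol-2-yl in place of 1,3-benzothiazol-2-yl on a sulfur, with 4-methyl-1,3-thiazol-2-yl in place of 1,3-benzothiazol-2-yl. The six-membered aromatic ring of carbon only thus leaves, and compound 3 again lacks it. Part of an at least 4.2-fold higher number from compound 1 to compound 2 (0.63 log units; beyond the scatter) is therefore expected to reverse, although a single step is thin support. The estimated change is an at least 2.5-fold lower number from compound 2 to compound 3 (0.39 log units; beyond the scatter), towards stronger inhibition. For compound 3 the estimated value is 8000 nM, with an expected range from 2500 nM to 20000 nM.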

Compound 3, half-maximal inhibitory concentration: > 20000 nM
Compound 3: a limit, no number (the forecaster's own chance of this, stated with the estimate: 25%); at least 2.5-fold (0.39 log units) between middle value and limit.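

In this assay compound 3 gives > 20000 nM, a limit of the assay and not a number. The six-membered aromatic ring of carbon only is therefore not required for a result at this limit: 4-methyl-1,3-thiazol-2-yl on the sulfur lacks that ring and still brings an at least 4.2-fold higher number from compound 1 to compound 3 (0.63 log units; beyond the scatter). The step between compound 2 and compound 3 cannot be read, because both stand at the same limit: the limit of > 20000 nM in this assay, at which 2 of the 3 values shown sit.

Only compound 1 has a measured number, at 4660 nM, so the compounds shown do not reveal which feature of its 1,3,4-thiadiazol-2-yl group matters. On these data alone, it also remains open how a plain methyl, a 2-aminoethyl chain or a 5-amino-1,3,4-thiadiazol-2-yl group on this sulfur would read.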